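This account rests on a few compounds, and the source may have more. Where it says the series, first, only, none or still open, it means among the compounds named here.

Going by the values given here, compound 1 `Cc1nc2c(N)ncnc2n1[C@@H]1O[C@H](CN(C)CCC(N)=O)[C@@H](O)[C@H]1O` gives 400 nM in an assay on isolated protein for inhibition of S-adenosylmethionine decarboxylase proenzyme (Homo sapiens) (a lower number here means a stronger inhibitor, a higher number a weaker inhibitor), the lowest of the three numbers known. Compound 2 `CCc1nc2c(N)ncnc2n1[C@@H]1O[C@H](CN(C)CCC(N)=O)[C@@H](O)[C@H]1O` gives 4000 nM in this assay, and a 10-fold higher number from compound 1 to compound 2 (1.00 log units; beyond the scatter) is a change on the core, not on the chain. Compound 3 `CN(CCCN)C[C@H]1O[C@@H](n2cnc3c(N)ncnc32)[C@H](O)[C@@H]1O` gives 500000 nM in this assay; it differs from compound 1 in two places, so its numbers show only that a plain amine chain without the core methyl sits far weaker. Compound 4 `Cc1nc2c(N)ncnc2n1[C@@H]1O[C@H](CN(C)CCCCON)[C@@H](O)[C@H]1O` carries 2-(aminooxy)ethyl in place of carbamoyl on a saturated chain carbon, two bonds along the chain from an amine nitrogen. Among the compounds with values here, no measured step bears directly on this change, so the expectation rests on compound 1 alone and is uncertain. Compound 4 is expected near 200 nM, between 20 nM and 2000 nM. That means an expected 2.0-fold lower number from compound 1 to compound 4 (0.30 log units; within the scatter).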

Compound 4, half-maximal inhibitory concentration: 5 nM
For compound 4 the middle estimate is 40-fold (1.60 log units) above the measured one; measured number outside the range, below it.
By their numbers in this assay, from the lowest: compound 4; then compound 1; then compound 2; then compound 3.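

Going by these compounds alone, the earlier step between measured compounds changed only the core, so this is the first measured sign that the chain on the amine nitrogen can also shift the number in this assay. Putting 2-(aminooxy)ethyl in place of carbamoyl gives an 80-fold lower number from compound 1 to compound 4 (1.90 log units; beyond the scatter), and compound 4 is the lowest of the four. No measurement shown explains this drop. The compounds shown do not separate the aminooxy end from the extra chain length, and a chain of the same length ending in a plain amine would bear on that.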